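This account rests on a few compounds, and the source may have more. Where it says the series, first, only, none or still open, it means among the compounds named here.

Measured compounds:
- compound 1, `CSc1cnc2ccccc2c1SCC#CCCl`, 2.5 ug/mL
- compound 2, `CSc1cnc2ccccc2c1[Se]CC#CCOC(=O)/C=C/c1ccccc1`, 17.8 ug/mL

In a functional assay on CCRF-CEM cells (Homo sapiens) for antiproliferative activity, with a stated time of 72 h (on this read-out lower numbers stand for stronger inhibition and higher numbers for weaker inhibition), compound 1 gives 2.5 ug/mL, while compound 2 gives 17.8 ug/mL. Compound 2 therefore stands at the higher of the two numbers, and its gap to compound 1 lies beyond the usual scatter of repeated measurements. The two compounds differ at more than one place, so no single structural step can be read from them.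

Compound 3, `CSc1cnc2ccccc2c1[Se]CC#CCOC(=O)c1ccc(C(=O)O)cc1`, is the unmeasured follow-up. Its change from compound 2 is 4-carboxyphenyl in place of 2-phenylethenyl on a carbonyl carbon. Within the data shown here, no measured pair shows this change, so there is no direct precedent for its effect. The expectation is a modest step from compound 2 to compound 3 toward a weaker, higher number in this assay, a 1.4-fold higher number from compound 2 to compound 3 (0.15 log units; within the scatter), though a result within the scatter would not surprise. Compound 3 is estimated at 25 ug/mL, with a plausible range from 8 ug/mL to 80 ug/mL.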

Compound 3, concentration for 50% inhibition: 4 ug/mL
Compound 3: middle estimate off by 6.3-fold (0.80 log units), on the high side; measured number outside the range, below it.
By their numbers in this assay, from the lowest: compounds 1 and 3 (each within the scatter of the next); then compound 2.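

In this assay, among these compounds, 4-carboxyphenyl in place of 2-phenylethenyl on a carbonyl carbon gives a 4.5-fold lower number from compound 2 to compound 3 (0.65 log units; beyond the scatter), the first step here that can be read at a single place. It shows that the number responds to what sits on this carbonyl carbon, even though both groups hold one six-membered aromatic ring of carbon only and one double bond outside aromatic rings. No measurement shown here bears on why the number moved.

From the compounds shown here alone, it remains open whether the carboxylic acid itself carries the step or a plain phenyl group would do the same, a question that the methyl ester of that acid could also help to settle. Going by these compounds, how an amine or a longer chain on this carbonyl carbon would behave is equally open.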